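Sugar in Place of Methyl: Tolerance in HEL Cells

A few compounds are considered here, and "the series" means these few. Any claim that something is new, unique, unknown or untested is made for them only; others in the source may bear on it.

Three measured compounds share a core with a long chain ending in a triple bond. Compound 1 `CCCCCCCCCCC#Cc1cc2cn(C)c(=O)nc2o1` carries a methyl on an aromatic nitrogen. In a functional assay on HEL cells (Homo sapiens) for cytotoxicity (a lower number here means that less compound is tolerated, a higher number that more compound is tolerated), compound 1 gives > 150000 nM, which is a limit of the assay rather than a number. Compound 2 `CCCCCCCCCCC#Cc1cc2cn([C@@H]3O[C@H](CO)[C@@H](O)[C@@H]3O)c(=O)nc2o1` differs from compound 1 by 3,4-dihydroxy-5-(hydroxymethyl)oxolan-2-yl in place of methyl on an aromatic nitrogen. In this assay compound 2 gives 46000 nM. The step is an at least 3.2-fold lower number from compound 1 to compound 2 (0.51 log units; beyond the scatter), so less of compound 2 is tolerated. Compound 3 `CCCCCCCCC#Cc1cc2cn(C)c(=O)nc2o1` differs from compound 1 by hydrogen in place of ethyl on a saturated chain carbon, eight bonds along the chain from a triple-bonded carbon. For compound 3 the read-out is again only a limit, > 175000 nM. Hence the step that the two limits leave unreadable from compound 1 to compound 3. Compound 4 `CCCCCCCCC#Cc1cc2cn([C@@H]3O[C@H](CO)[C@@H](O)[C@@H]3O)c(=O)nc2o1` is not yet measured; it stands to compound 3 as compound 2 stands to compound 1, the same change 3,4-dihydroxy-5-(hydroxymethyl)oxolan-2-yl in place of methyl on an aromatic nitrogen at the same place. Given that the change gave an at least 3.2-fold lower number from compound 1 to compound 2 (0.51 log units; beyond the scatter), the step is expected to be an at least 3.5-fold lower number from compound 3 to compound 4 (0.54 log units; beyond the scatter). Compound 4 is therefore estimated at 50000 nM, between 15000 nM and 150000 nM. The range is wide since compound 3 is known only as the limit > 175000 nM.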

Compound 4, minimum cytotoxic concentration: 49000 nM
Compound 4: the middle estimate sits 1.0-fold (0.01 log units) above what was measured; the range from low to high includes it.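

In this assay, putting 3,4-dihydroxy-5-(hydroxymethyl)oxolan-2-yl in place of methyl on the aromatic nitrogen again lowers the number on the second core, with an at least 3.5-fold lower number from compound 3 to compound 4 (0.55 log units; beyond the scatter), so less compound is tolerated with this group on both cores: the same change on two cores in this assay, an at least 3.2-fold lower number (0.51 log units; beyond the scatter) from compound 1 to compound 2 and an at least 3.5-fold lower number (0.55 log units; beyond the scatter) from compound 3 to compound 4; the limit leaves it open whether they differ

The two compounds that carry this group also lie within the scatter of each other, with a 1.1-fold higher number from compound 2 to compound 4 (0.03 log units; within the scatter). This does not show how large the change is on either core or whether the two sizes match, as the two methyl compounds give only limits of the assay.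

Only two chain lengths are shown, so it remains open whether the same change would carry over to a core with a longer chain. As far as these compounds go, it is also open how this assay would read with an amine or a carboxylic acid on the group at the aromatic nitrogen.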